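A few compounds are considered here, and "the series" means these few. Any claim that something is new, unique, unknown or untested is made for them only; others in the source may bear on it.

Compound 1 `COc1cc(N(Cc2nc3ccccc3[nH]2)C(=O)c2ccccc2)cc(OC)c1OC` — in a functional assay on MCF7 cells (Homo sapiens) for inhibition, read by MTT assay, with a stated time of 48 h (on this read-out higher numbers stand for weaker inhibition and lower numbers for stronger inhibition), compound 1 gives > 50000 nM, a limit of the assay and not a number.
Compound 2 `COc1cc(N(Cc2nc3ccccc3[nH]2)C(=O)c2ccc(C)cc2)cc(OC)c1OC` — in this assay compound 2 gives 49300 nM.

In this assay, going by the values given here, compound 2 holds the only numbered value; the other entry is a limit (the limit of > 50000 nM in this assay, at which 1 of the 2 values shown sits). Among the compounds with values here, the one measured step, an at least 1.0-fold lower number from compound 1 to compound 2 (0.00 log units; that floor lies within the scatter), sits within the scatter. Compound 3 `COc1ccc(C(=O)N(Cc2nc3ccccc3[nH]2)c2cc(OC)c(OC)c(OC)c2)cc1OC` carries 3,4-dimethoxyphenyl in place of 4-methylphenyl on a carbonyl carbon. Within the data shown here, no measured step exchanges one aryl group for another on the carbonyl carbon, so the measured step gives no direction for this change. For compound 3 the expected step is a 1.2-fold lower number from compound 2 to compound 3 (0.09 log units; within the scatter), nothing beyond the scatter. The estimate for compound 3 is 40000 nM, with a range from 15000 nM to 80000 nM.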

Compound 3, half-maximal inhibitory concentration: > 50000 nM
Compound 3 gave a limit, no number; the forecaster's own chance of this, stated with the estimate: 40%; middle value at least 1.2-fold (0.09 log units) away from the limit.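

In this assay compound 3 returns to a limit of the assay, not a number: the limit of > 50000 nM in this assay, at which 2 of the 3 values shown sit.

Exchanging 4-methylphenyl for 3,4-dimethoxyphenyl on the carbonyl carbon gives an at least 1.0-fold higher number from compound 2 to compound 3 (0.00 log units; that floor lies within the scatter), so this first look at a larger aryl group at this place does not separate the two compounds. The step between compound 1 and compound 3 cannot be read.

As far as these compounds go, whether any group on this carbonyl carbon moves the number beyond the scatter remains open. Also open, from the compounds shown here alone, is what an amine or a carboxylic acid on this aryl group would do in this assay.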